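The source may report more compounds than this note shows. Statements on the series, on what has been measured and on what is new or still open speak of the compounds shown alone.

Compound 1 `COc1ccc(-c2cc(/C=C/C(=O)c3ccc(N)cc3)[nH]n2)cc1`: 1900 nM
Compound 2 `COc1cc(-c2cc(/C=C/C(=O)c3ccc(N)cc3)[nH]n2)cc(OC)c1OC`: 1870 nM

In a functional assay on UACC-257 cells (Homo sapiens) for inhibition, read by sulforhodamine B assay, with a stated time of 48 h (a lower number here means a stronger inhibitor of growth, a higher number a weaker inhibitor of growth), compound 1 gives 1900 nM and compound 2 gives 1870 nM. Compound 2 holds the lower of the two numbers, but its gap to compound 1 lies within the scatter, so the two compounds cannot be told apart on these data. Compound 3 `COc1ccc(-c2cc(/C=C/C(=O)c3ccc(N)cc3)[nH]n2)cc1OC` differs from compound 2 in one place: hydrogen in place of methoxy on an aromatic carbon. Among the measured compounds shown here, no step between measured compounds shows what taking away a methoxy group does. Compound 1, carrying fewer methoxy groups on that ring, and compound 2, carrying more, give numbers within the scatter of each other, so the count of methoxy groups has not shifted the result so far. In this assay compound 3 is therefore expected to land close to compound 2, with a step of a 1.0-fold higher number from compound 2 to compound 3 (0.01 log units; within the scatter) that stays within the scatter. The estimate for compound 3 is 1900 nM, with a range from 900 nM to 4000 nM.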

Compound 3, concentration for 50% growth inhibition: 6460 nM
Compound 3: the middle estimate sits 3.4-fold (0.53 log units) below what was measured; measured number outside the range, above it.
By their numbers in this assay, from the lowest: compounds 2 and 1 (each within the scatter of the next); then compound 3.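

In this assay, removing the methoxy group from this aromatic carbon, which stands ortho to a methoxy group and meta to a large group, does change the result, giving a 3.5-fold higher number from compound 2 to compound 3 (0.54 log units; beyond the scatter). Adding a methoxy group to the ring of the compound with fewer of them also gives a 3.4-fold higher number from compound 1 to compound 3 (0.53 log units; beyond the scatter), so the number does not follow the count of methoxy groups: compound 3 has the middle count but the weakest growth inhibition, whereas compounds 1 and 2 remain within the scatter of each other. Nothing available here explains this pattern.

From the compounds shown here alone, it remains open whether a hydroxyl group or a chlorine atom on this carbon would give a number closer to compound 2 or to compound 3. The compounds shown also leave open whether moving the methoxy groups to other carbons of the ring would matter as much.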